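A Methoxy Swap on Compound 1

This account rests on a few compounds, and the source may have more. Where it says the series, first, only, none or still open, it means among the compounds named here.

Measured in a functional assay on DU-145 cells (Homo sapiens) for inhibition, read by trypan blue exclusion, with a stated time of 96 h; a lower number here means a stronger inhibitor of growth, a higher number a weaker inhibitor of growth:
Compound 1 (`CSc1ccc(/C=C(\C(=O)c2ccc(Br)cc2)S(=O)(=O)Cc2ccc(F)cc2)cc1`): 50000 nM
Compound 2 (`COc1cc(/C=C(/Sc2ccc(Br)cc2)C(=O)c2ccc(Br)cc2)ccc1F`): 10000 nM
Compound 3 (`Cc1ccsc1/C=C(/SCc1ccc(Cl)cc1Cl)C(=O)c1ccc(Cl)cc1`): 10000 nM

Compound 1 has the highest number of the three, so it is the weakest inhibitor of growth here. Compound 4 (`COc1ccc(/C=C(\C(=O)c2ccc(Br)cc2)S(=O)(=O)Cc2ccc(F)cc2)cc1`) is compound 1 with a single change: methoxy in place of methylsulfanyl on an aromatic carbon, para to a large group (methoxy in place of methylsulfanyl on an aromatic carbon). Within the data shown here, no measured pair shows this swap, so the data give no direct guide to its size. The two groups are alike in the counts, so only a small change is expected. The estimated result is a 1.7-fold lower number from compound 1 to compound 4 (0.22 log units; within the scatter), toward a lower number but probably not beyond the usual scatter. For compound 4 the estimated value in this assay is 30000 nM, with an expected range of 8000 nM to 80000 nM.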

Compound 4, concentration for 50% growth inhibition: 25000 nM
The estimate for compound 4 lay 1.2-fold (0.08 log units) above the measured number; low and high end bracket the measured number.
By their numbers in this assay, from the lowest: compounds 2 and 3 (each within the scatter of the next); then compounds 4 and 1 (each within the scatter of the next).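

In this assay, among these compounds, placing methoxy in place of methylsulfanyl on this aromatic carbon gives a 2.0-fold lower number from compound 1 to compound 4 (0.30 log units; within the scatter), the first direct reading of this swap. At this position, on this core, the two groups cannot be told apart by this measure, so the sulfur of methylsulfanyl is not required for the growth inhibition seen with compound 1. Nothing shown gives a reason for this result. Going by these compounds, whether an amine or a longer chain such as ethoxy at this position would shift the number beyond the scatter remains open. So does whether this swap would read the same on the other cores shown.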